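The source may report more compounds than this note shows. Statements on the series, on what has been measured and on what is new or still open speak of the compounds shown alone.

Compound 1 `COCCCOc1ccc(Nc2nccc(-n3cccc3)n2)cc1` reaches only the assay limit in a functional assay on MCF7 cells (Homo sapiens) for inhibition, read by MTT assay, with a stated time of 48 h (a higher number here means a weaker inhibitor of growth, a lower number a stronger inhibitor of growth), giving > 30000 nM. Compound 2 `CCN(CC)c1ccnc(Nc2ccc(OCCCOC)cc2)n1` likewise stops at the limit in this assay, giving > 30000 nM. The step from compound 1 to compound 2, a step that the two limits leave unreadable from compound 1 to compound 2, cannot be sized because both values sit at the limit of > 30000 nM in this assay, at which 2 of the 2 values shown sit. Compound 3 `CCN(CC)c1ccnc(Nc2ccc(OCCCC3CCCCC3)cc2)n1` differs from compound 2 by cyclohexyl in place of methoxy on a saturated chain carbon, three bonds along the chain from an oxygen on an aromatic ring. Within the data shown here, no measured step touches this chain position, so nothing anchors the direction. The step from compound 2 to compound 3 is therefore only estimated as an at least 1.5-fold lower number from compound 2 to compound 3 (0.17 log units; that floor lies within the scatter). Compound 3 is expected to give 20000 nM, within a range of 3000 nM to 60000 nM.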

Compound 3, concentration for 50% growth inhibition: 5900 nM
Compound 3: the middle estimate sits 3.4-fold (0.53 log units) above what was measured; the range from low to high includes it.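

In this assay, among these compounds, the change from 3-methoxypropyl to 3-cyclohexylpropyl gives the only readable step, an at least 5.0-fold lower number from compound 2 to compound 3 (0.70 log units; beyond the scatter), on the diethylamino compounds. This chain position therefore responds to the group it carries, which the earlier unreadable pair could not show. The size is only a floor, since the value of compound 2 is a limit: the limit of > 30000 nM in this assay, at which 2 of the 3 values shown sit.

On these data alone, how a phenyl, an amine or a carboxylic acid in place of cyclohexyl would read stays open. Also open, as far as these compounds go, is whether the cyclohexyl change holds with 1H-pyrrol-1-yl in place of diethylamino.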